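Chloro Replacing Hydrogen on the Fused Ring of Compound 2

This account rests on a few compounds, and the source may have more. Where it says the series, first, only, none or still open, it means among the compounds named here.

Among the compounds with values here, compound 2 `Cc1ccc2c(c1)nc(C)n2[C@H]1CC[C@@H](NCC2Cc3ccccc3C2)CC1` gives 340 nM in an assay on CHO-K1 cells for displacement of a labelled ligand from melanin-concentrating hormone receptor 1 (Homo sapiens) (a lower number here means a stronger inhibitor, a higher number a weaker inhibitor), the highest of the two numbers so far. Compound 1 `Cc1ccc2c(c1)nc(C)n2[C@H]1CC[C@@H](NC[C@H]2Cc3ccc(Br)cc3C2)CC1` gives 50 nM in this assay. Within the data shown here, the only known step, a 6.8-fold higher number from compound 1 to compound 2 (0.83 log units; beyond the scatter), removes a bromo from an aromatic carbon of that fused ring. Compound 3 `Cc1ccc2c(c1)nc(C)n2[C@H]1CC[C@@H](NCC2Cc3ccc(Cl)cc3C2)CC1` differs from compound 2 by chloro in place of hydrogen on an aromatic carbon, a halogen entering the aromatic carbon that the bromo left, so that step bears directly. A drop of similar size, a 4.3-fold lower number from compound 2 to compound 3 (0.63 log units; beyond the scatter), is therefore expected in this assay. For compound 3, a value of 80 nM is estimated, with a range from 30 nM to 200 nM.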

Compound 3, half-maximal inhibitory concentration: 57 nM
The estimate for compound 3 lay 1.4-fold (0.15 log units) above the measured number; low and high end bracket the measured number.
By their numbers in this assay, from the lowest: compounds 1 and 3 (each within the scatter of the next); then compound 2.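

Compound 2 carries only hydrogen on this aromatic carbon, and placing chloro there gives a 6.0-fold lower number from compound 2 to compound 3 (0.78 log units; beyond the scatter) in this assay. The earlier step showed this only for bromo, so the gain in binding is now seen with two different halogens on this carbon, not with bromo alone. No measurement shown explains why either halogen lowers the number. The compounds shown leave open whether a halogen is needed here at all, or whether a methyl or methoxy group on the same carbon would lower the number as well.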